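The source may report more compounds than this note shows. Statements on the series, on what has been measured and on what is new or still open speak of the compounds shown alone.

Measured in a functional assay (aorta) with Rattus norvegicus as the target; a higher number here means that more compound is needed for the effect, a lower number that less compound is needed:
- compound 1 `CCC(CC)NC1=NS(=O)(=O)c2cc(Cl)ccc2N1`: 93.6 uM
- compound 2 `CC(C)C(C)NC1=NS(=O)(=O)c2cc(I)ccc2N1`: 0.94 uM

Of these two compounds, compound 2 at 0.94 uM has the lower number, and the gap to compound 1 lies well beyond the scatter. The two differ in more than one place, so their gap cannot be assigned to any single change.

The next compound to be measured is compound 3 `CCC(CC)NC1=NS(=O)(=O)c2cc(I)ccc2N1`. Relative to compound 2, its structural change is pentan-3-yl in place of 1,2-dimethylpropyl on an amine nitrogen. For the measured compounds named here, no measured pair isolates this change, so the expectation rests on weak evidence. Compound 1 also carries pentan-3-yl and sits high at 93.6 uM, which points towards a higher number in this assay rather than a lower one. The expected step of a 3.2-fold higher number from compound 2 to compound 3 (0.50 log units; beyond the scatter) is a moderate rise, probably beyond the scatter but much smaller than the gap between the two measured compounds. For compound 3 the estimated value is 3 uM, with an expected range of 0.8 uM to 15 uM.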

Compound 3, concentration for half-maximal effect: 79.1 uM
Compound 3: middle estimate off by 26-fold (1.42 log units), on the low side; measured number above the stated range.
By their numbers in this assay, from the lowest: compound 2; then compounds 3 and 1 (each within the scatter of the next).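

In this assay the amine substituent now has a matched pair: an 84-fold higher number from compound 2 to compound 3 (1.93 log units; beyond the scatter) with pentan-3-yl in place of 1,2-dimethylpropyl. The two groups have the same atoms joined differently, with the same heavy-atom count and no ring, so on this amine nitrogen the arrangement of the carbons alone goes with a large change, not just the number of carbons. With pentan-3-yl held fixed, iodo in place of chloro on an aromatic carbon gives a 1.2-fold lower number from compound 1 to compound 3 (0.07 log units; within the scatter), so that exchange leaves no readable difference in this setting, and the low number of compound 2 cannot be credited to iodo alone. Nothing measured alongside these compounds explains why the amine change has so large a step.

The compounds shown pair the two halogens only with pentan-3-yl, so it remains open whether the exchange of iodo for chloro is equally silent with 1,2-dimethylpropyl on the amine nitrogen. Also open, as far as these compounds go, is where a cyclopentyl group, a tert-butyl group or a longer unbranched chain on that nitrogen would fall relative to these two groups.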